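The source may report more compounds than this note shows. Statements on the series, on what has been measured and on what is new or still open speak of the compounds shown alone.

Compound 1 `Cn1cc(SCC(=O)Nc2ccccc2Cl)c2ccccc21` and compound 2 `Cn1cc(SCC(=O)Nc2cccc(Cl)c2)c2ccccc21` share one core and differ only in the chlorophenyl carried on the amide-type nitrogen. In an ADME assay on HEK-293T cells (Homo sapiens) for cytotoxicity, read by CCK-8 assay, with a stated time of 48 h (on this read-out higher numbers stand for lower toxicity in this test and lower numbers for higher toxicity in this test), compound 1 gives > 100000 nM, which is a limit of the test and not a number. In this assay compound 2 likewise gives > 100000 nM, again a limit. The step that the two limits leave unreadable from compound 1 to compound 2 is therefore not readable, both values sitting at the limit of > 100000 nM in this assay, at which 2 of the 2 values shown sit. Compound 2 thus stands only at a limit in this assay, with no numerical placing within the pair. Compound 3 `Cn1cc(SCC(=O)Nc2ccc(Cl)cc2)c2ccccc21` completes the set of isomers: 4-chlorophenyl in place of 3-chlorophenyl on an amide-type nitrogen. Within the data shown here, the single measured step bears on this change only by showing that exchanging one chlorophenyl for another left both compounds at the limit. No step beyond the scatter is expected for a step that the limit leaves unreadable from compound 2 to compound 3, and a limit is again the likeliest report. Compound 3 is estimated at 150000 nM in this assay, within a range of 60000 nM to 400000 nM.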

Compound 3, half-maximal cytotoxic concentration: > 100000 nM
Compound 3: a limit, no number; the forecaster's own chance of this, stated with the estimate: 85%; the middle value lies beyond the limit too.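

In this assay compound 1, compound 2 and compound 3 all stand at a limit, and no step can be read among them. The compounds shown leave open how these three chlorophenyl isomers would rank, and whether any would give a numerical half-maximal cytotoxic concentration.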